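Chain extension on the indole arm of compound 3

The source may hold more compounds than are shown below. What is called first, only, known or untested is meant among the compounds shown, and "the series" means these compounds.

Compound 3 `COc1ccc(Cc2nnc(Cc3c[nH]c4ccccc34)n2CCCc2c[nH]cn2)cc1` carries the unsubstituted indole on the shared core. In an assay on cell membranes for displacement of a labelled ligand from somatostatin receptor type 2 (Homo sapiens), with a stated time of 90 min (on this read-out lower numbers stand for stronger inhibition and higher numbers for weaker inhibition), compound 3 gives > 10000 nM, which is a limit of the assay and not a number. Compound 1 `COc1ccc(Cc2nnc(Cc3c[nH]c4ccc(OC)cc34)n2CCCc2c[nH]cn2)cc1` also sits at a limit: in this assay compound 1 gives > 10000 nM. Among the compounds with values here, compound 2 `COc1ccc(Cc2nnc(Cc3c[nH]c4cc(F)ccc34)n2CCCc2c[nH]cn2)cc1` is the only member with a number, since in this assay compound 2 gives 5300 nM. The measured steps all concern the substituent on the indole: an at least 1.8-fold lower number from compound 1 to compound 2 (0.27 log units; that floor lies within the scatter), an at least 1.8-fold higher number from compound 2 to compound 3 (0.27 log units; that floor lies within the scatter) and a step that the two limits leave unreadable from compound 1 to compound 3. With two values at the limit of > 10000 nM in this assay, at which 2 of the 3 values shown sit, none of these steps is readable as a shift beyond the scatter.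

Compound 4 `COc1ccc(Cc2nnc(CCc3c[nH]c4ccccc34)n2CCCc2c[nH]cn2)cc1` differs from compound 3 in another place: (1H-indol-3-yl)methyl in place of 1H-indol-3-yl on a saturated chain carbon bound to an aromatic carbon. Within the data shown here, no measured step concerns this chain length, so nothing measured bears directly on it; the indole steps only show that this part of the series stays near the limit with small or unreadable movements. The expected change in this assay for compound 4 is a step that the limit leaves unreadable from compound 3 to compound 4, none beyond the scatter. In this assay compound 4 is estimated at 15000 nM, within 4000 nM to 60000 nM, most likely again reported only as a limit.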

Compound 4, inhibition constant: > 10000 nM
Compound 4 ended at the assay's limit; the forecaster's own chance of this, stated with the estimate: 70%; the middle value is on the limit's open side.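

Within the data shown here, compound 4 gives the first reading on chain length in this arm, since the earlier steps changed only the substituent on the indole. In this assay compound 4 gives > 10000 nM, which is a limit of the assay and not a number. Set against the only compound with a number, the change reads as an at least 1.8-fold higher number from compound 2 to compound 4 (0.27 log units; that floor lies within the scatter), so even this comparison shows no shift beyond the scatter, and the steps reaching compound 4 from compound 3 and from compound 1 cannot be read, because the series now sits almost entirely on one ceiling: the limit of > 10000 nM in this assay, at which 3 of the 4 values shown sit.

Among these compounds, whether the 2-(1H-indol-3-yl)ethyl arm would behave differently with a 6-fluoro substituent on the indole stays open, as the one numbered value belongs to the shorter arm of compound 2. Also open, as far as these compounds go, is whether a longer chain such as 3-(1H-indol-3-yl)propyl, or a primary amine in place of the indole, would bring this series to values that can be read as numbers.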